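Butyl in Place of Methoxy on the Aryl Ether Chain

The compounds below may be only part of what the source reports. "The series", "measured", "known", "first", "only" and "open" are said of these compounds alone.

Measured compounds:
compound 1 `O=C1CC(c2ccccc2OCc2cccc(F)c2)Oc2ccccc21`: 13200 nM in a functional assay on J774.A1 cells (Mus musculus) for inhibition, read by Griess assay, with stated times of 1 h and 24 h; on this read-out lower numbers stand for stronger inhibition and higher numbers for weaker inhibition
compound 2 `COCOc1ccccc1C1CC(=O)c2ccccc2O1`: 35200 nM in this assay

Compound 2 gives the highest of the two numbers; its nearest neighbour is compound 1, with a 2.7-fold higher number from compound 1 to compound 2 (0.43 log units; beyond the scatter). Compound 3 `CCCCCOc1ccccc1C1CC(=O)c2ccccc2O1` differs from compound 2 by butyl in place of methoxy on a saturated chain carbon bound to an oxygen on an aromatic ring. Among the measured compounds shown here, the only step that bears on this site is the one from compound 1 to compound 2, where a larger group on that carbon went with the lower number. A modest step downward is therefore expected, with a 1.8-fold lower number from compound 2 to compound 3 (0.25 log units; within the scatter). Compound 3 is estimated at 20000 nM, within 8000 nM to 50000 nM.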

Compound 3, half-maximal inhibitory concentration: 39300 nM
Compound 3: the middle estimate sits 2.0-fold (0.29 log units) below what was measured, and the stated range covers the measured number.
By their numbers in this assay, from the lowest: compound 1; then compounds 2 and 3 (each within the scatter of the next).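

In this assay, butyl in place of methoxy on this carbon gives no separable change (a 1.1-fold higher number from compound 2 to compound 3 (0.05 log units; within the scatter)), so a larger chain here does not by itself go with a lower number, as the earlier step alone might have suggested. Compound 1, with 3-fluorophenyl on this carbon, stands apart from butyl as well as from methoxy (a 3.0-fold higher number from compound 1 to compound 3 (0.47 log units; beyond the scatter)). No evidence at hand explains these numbers. The compounds shown leave open whether the lower number of compound 1 goes with its aromatic ring or with its fluorine, and how a plain phenyl, a longer chain or an amine on this carbon would read.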